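The compounds below may be only part of what the source reports. "The series", "measured", "known", "first", "only" and "open" are said of these compounds alone.

Working notes on the series, values in an ADME assay on RAW264.7 cells (Mus musculus) for cytotoxicity, read by MTT assay, with a stated time of 24 h (on this read-out lower numbers stand for higher toxicity in this test and higher numbers for lower toxicity in this test), as measured:

- compound 1 `CC/C=C\C[C@H]1C(=O)C=C[C@H]1CC(=O)OCC` gives 146 uM
- compound 2 `CC/C=C\C[C@H]1C(=O)C=C[C@H]1CC(=O)OCCCCC` gives 37 uM
- compound 3 `CC/C=C\C[C@H]1C(=O)C=C[C@H]1CC(=O)OCCOCCOCCO` gives 162 uM

Compound 2 holds the lowest number of the three, and it lies beyond the scatter from both of the others. Compound 4 `CC/C=C\C[C@H]1C(=O)C=C[C@H]1CC(=O)OCCOCCOC` shares the core and departs from compound 2 in one place: 2-methoxyethoxy in place of propyl on a saturated chain carbon, two bonds along the chain from an oxygen next to a carbonyl group (on a saturated chain carbon, two bonds along the chain from an oxygen next to a carbonyl group).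

The closest measured precedent is a 4.4-fold higher number from compound 2 to compound 3 (0.64 log units; beyond the scatter), a modest step that puts 2-(2-hydroxyethoxy)ethoxy in place of propyl at that same carbon. Two further steps frame it. The first, a 3.9-fold lower number from compound 1 to compound 2 (0.60 log units; beyond the scatter), is also modest and beyond the scatter, while a 1.1-fold higher number from compound 1 to compound 3 (0.05 log units; within the scatter) stays within the scatter. Among the compounds with values here, no measured compound carries 2-methoxyethoxy, so this transfer remains uncertain.

A modest rise is therefore expected, somewhat smaller than the precedent. The expected step is a 3.2-fold higher number from compound 2 to compound 4 (0.51 log units; beyond the scatter) in this assay and it would take the number back toward the upper pair. For compound 4 the estimate is 120 uM as the expected middle, with an expected range from 60 uM to 230 uM in this assay for the coming measurement.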

Compound 4, half-maximal toxic concentration: 161 uM
For compound 4 the middle estimate is 1.3-fold (0.13 log units) below the measured one, and the stated range covers the measured number.
By their numbers in this assay, from the lowest: compound 2; then compounds 1, 4 and 3 (each within the scatter of the next).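

In this assay, the rise at this carbon does not depend on the longer 2-(2-hydroxyethoxy)ethoxy chain: 2-methoxyethoxy in place of propyl gives a 4.4-fold higher number from compound 2 to compound 4 (0.64 log units; beyond the scatter), a step of the same printed size as a 4.4-fold higher number from compound 2 to compound 3 (0.64 log units; beyond the scatter), and the enter group here is listed with 0 hydrogen-bond donors. Within the data shown here, the terminal hydroxymethyl of compound 3 can go without a readable change, with a 1.0-fold lower number from compound 3 to compound 4 (0.00 log units; within the scatter), and a 1.1-fold higher number from compound 1 to compound 4 (0.04 log units; within the scatter) leaves compound 4 level with compound 1, so compounds 1, 3 and 4 now form a group of three within the scatter, and compound 2 is the one compound that stands apart. Nothing available explains why the number moves at this carbon.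

The compounds shown leave open whether a longer alkyl chain, such as octyl, in place of propyl would take the number lower than the value for compound 2, or whether the low value belongs to pentyl alone. They also leave open whether a terminal amine or a carboxylic acid on the chain would stay level with compounds 1, 3 and 4.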